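The source may report more compounds than this note shows. Statements on the series, on what has been measured and on what is new or still open speak of the compounds shown alone.

Measured compounds:
- compound 1, `Cc1cccc(OCCCOc2ccc(-c3ccccc3CCC(=O)NS(=O)(=O)c3cccs3)cc2)c1`: 53 nM
- compound 2, `Cc1cccc(OCCCOc2ccc(-c3ccccc3CC(C)C(=O)NS(=O)(=O)c3cccs3)cc2)c1`: 340 nM

These two compounds share one core and were both tested in an assay on isolated protein for binding affinity to prostaglandin E2 receptor EP3 subtype (Homo sapiens); on this read-out higher numbers stand for weaker inhibition and lower numbers for stronger inhibition. Compound 1 gives 53 nM in this assay. Compound 2 carries one more methyl and gives 340 nM. The step between them, a 6.4-fold higher number from compound 1 to compound 2 (0.81 log units; beyond the scatter), is the only one available, and it makes compound 2 the weaker binder of the pair, with compound 1 as its closest neighbour.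

Compound 3, `Cc1cccc(OCCCOc2ccc(-c3ccccc3CC(C)(C)C(=O)NS(=O)(=O)c3cccs3)cc2)c1`, has not yet been measured in this assay. It differs from compound 2 by methyl in place of hydrogen on a saturated chain carbon bound to a carbonyl carbon and two saturated chain carbons. This is a second methyl added at the same place where the first one already went in from compound 1 to compound 2. Among the compounds with values here, the only step that bears on it is a 6.4-fold higher number from compound 1 to compound 2 (0.81 log units; beyond the scatter), which weakened binding noticeably. A further methyl at that place is therefore expected to weaken binding again, by a step of roughly a 2.6-fold higher number from compound 2 to compound 3 (0.42 log units; beyond the scatter). For compound 3 the expected value in this assay is 900 nM, with a likely range from 250 nM to 3500 nM.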

Compound 3, inhibition constant: 440 nM
The estimate for compound 3 lay 2.0-fold (0.31 log units) above the measured number; low and high end bracket the measured number.
By their numbers in this assay, from the lowest: compound 1; then compounds 2 and 3 (each within the scatter of the next).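

In this assay, the second methyl on this saturated chain carbon, bound to a carbonyl carbon and two saturated chain carbons, comes with a 1.3-fold higher number from compound 2 to compound 3 (0.11 log units; within the scatter), so compound 2 and compound 3 cannot be told apart. The first methyl at this place had given a 6.4-fold higher number from compound 1 to compound 2 (0.81 log units; beyond the scatter), so the two additions do not act alike: the clear loss seen with the first does not repeat with the second, and a carbon carrying two methyls fares no differently from one carrying a single methyl. Nothing available explains this difference between the first and second methyl.

Going by these compounds, it remains open whether a larger group on this carbon, such as an ethyl or a cyclopropyl ring built on it, would stay level with compound 2 and compound 3 or move away from them. On these data alone, it is equally open whether a fluorine or a hydroxyl in place of the added methyl would bring the number back towards that of compound 1 at 53 nM, or whether any replacement at this carbon does so.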